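The source may hold more compounds than are shown below. What is called first, only, known or untested is meant among the compounds shown, and "the series" means these compounds.

Measured so far in an ADME assay on HCT-116 cells (Homo sapiens) for cytotoxicity, read by CellTiter-Glo, with a stated time of 72 h; a lower number here means a stronger inhibitor, a higher number a weaker inhibitor:
Compound 1 `Cc1cccc(S(=O)(=O)N2CCC(N3CCC(C)CC3)CC2)c1`: > 5000 nM, a limit
Compound 2 `Cc1nc(Cl)sc1S(=O)(=O)N1CCC(N2CCC(C)CC2)CC1`: > 10000 nM, a limit

Compound 2 stands only at a limit, > 10000 nM, and so has no number of its own. Compound 3 `CC1CCN(C2CCN(S(=O)(=O)c3cccc(Br)c3)CC2)CC1` is not yet measured. Its difference from compound 2 is 3-bromophenyl in place of 2-chloro-4-methyl-1,3-thiazol-5-yl on a sulfonyl sulfur.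

For the measured compounds named here, the only measured step at this place is a step that the two limits leave unreadable from compound 1 to compound 2, so it offers no size to carry over. Compound 1 also gives only a limit, > 5000 nM. With no number in the series, the expectation rests on these two limits alone, and no step beyond the scatter is expected in this assay. The estimated step is a number no higher from compound 2 to compound 3 (the limit leaves the size open), and its direction is not established. The estimate for compound 3 is 10000 nM, with an expected range of 4000 nM to 25000 nM. A report of only a limit is the likeliest outcome.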

Compound 3, half-maximal inhibitory concentration: > 5000 nM
Compound 3: no number, only a limit; the forecaster's own chance of this, stated with the estimate: 80%; the middle value does not contradict the limit.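

In this assay compound 3 gives > 5000 nM, a limit and not a number. No step can be read from compound 3 to compound 2 or compound 1, as all three stand only at limits. The compounds shown leave open how 3-bromophenyl, 3-methylphenyl and 2-chloro-4-methyl-1,3-thiazol-5-yl on the sulfonyl sulfur compare in this assay.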